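Series notes: expected binding of compound 4

This account rests on a few compounds, and the source may have more. Where it says the series, first, only, none or still open, it means among the compounds named here.

Measured so far:
compound 1 `CC1(c2ccc(F)cc2)NC(=O)N(CC(O)CN2CCN(c3ccccc3Cl)CC2)C1=O` gives 47 nM
compound 2 `CC1(c2ccc(F)cc2)NC(=O)N(CC(O)CN2CCN(c3ccccc3C#N)CC2)C1=O` gives 14 nM
compound 3 `CC1(c2ccc(F)cc2)NC(=O)N(CC(O)CN2CCN(c3ccc(Cl)cc3)CC2)C1=O` gives 908 nM

On an assay on HEK293 cells for displacement of a labelled ligand from 5-hydroxytryptamine receptor 7 (Homo sapiens) (on this read-out lower numbers stand for stronger inhibition and higher numbers for weaker inhibition), the highest number of the three belongs to compound 3. Both steps toward it are large: a 19-fold higher number from compound 1 to compound 3 (1.29 log units; beyond the scatter); a 65-fold higher number from compound 2 to compound 3 (1.81 log units; beyond the scatter). Compound 4 `CC1(c2ccc(F)cc2)NC(=O)N(CC(O)CN2CCN(c3ccc(Cl)c(Cl)c3)CC2)C1=O` differs from compound 3 by chloro in place of hydrogen on an aromatic carbon. Going by the values given here, no measured step adds a second group to this aryl ring; the steps of a 3.4-fold lower number from compound 1 to compound 2 (0.53 log units; beyond the scatter) and the two above show only that the aryl substitution pattern moves the number strongly, without indicating what a further chloro on the 4-chlorophenyl would do. A modest step is therefore expected, a 1.8-fold lower number from compound 3 to compound 4 (0.26 log units; within the scatter), with the direction uncertain and a slight lean toward a lower number. For compound 4 the estimate is 500 nM, range 150 nM to 1500 nM.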

Compound 4, inhibition constant: 141 nM
Compound 4: the middle estimate sits 3.5-fold (0.55 log units) above what was measured; the measured number lies below the stated range.
By their numbers in this assay, from the lowest: compound 2; then compound 1; then compound 4; then compound 3.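

In this assay, chloro in place of hydrogen on the aromatic carbon ortho to a chloro group turns 4-chlorophenyl into 3,4-dichlorophenyl and gives a lower number (a 6.4-fold lower number from compound 3 to compound 4 (0.81 log units; beyond the scatter)), so a second group on this aryl ring moves the number too. Going by these compounds alone, the 3,4-dichlorophenyl still stays behind both aryl groups of the earlier compounds (a 3.0-fold higher number from compound 1 to compound 4 (0.48 log units; beyond the scatter); a 10-fold higher number from compound 2 to compound 4 (1.00 log units; beyond the scatter)). Nothing available explains the gain. From the compounds shown here alone, whether a methoxy or an amine on that carbon would act as chloro does remains open. Also open, going by these compounds, is whether the same added chloro would lower the number on the 2-chlorophenyl of compound 1.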